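Ethyl on the hydroxy oxygen of compound 2

A few compounds are considered here, and "the series" means these few. Any claim that something is new, unique, unknown or untested is made for them only; others in the source may bear on it.

For the measured compounds named here, in a functional assay on SK-BR-3 cells (Homo sapiens) for cytotoxicity, read by sulforhodamine B assay, with a stated time of 3 days (on this read-out higher numbers stand for an effect only at larger amounts of compound and lower numbers for an effect already at smaller amounts), compound 1 `Cc1coc(-c2ccc3c(c2O)CCCC3(C)C)c1C(=O)O` gives 0.7 uM and compound 2 `Cc1coc(-c2ccc3c(c2O)CCCC3(C)C)c1CO` gives 21.3 uM, the higher of the only two numbers so far. Going by the values given here, the single measured step, a 30-fold higher number from compound 1 to compound 2 (1.48 log units; beyond the scatter), is large and beyond the scatter. It comes from hydroxymethyl in place of carboxy on an aromatic carbon.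

Compound 3 `CCOc1c(-c2occ(C)c2CO)ccc2c1CCCC2(C)C` keeps the hydroxymethyl of compound 2 and differs elsewhere: ethyl in place of hydrogen on an oxygen on an aromatic ring. This is ethyl in place of hydrogen on an oxygen on an aromatic ring, or hydroxy to ethoxy. Among the compounds with values here, no measured step touches that oxygen, so the change from compound 1 to compound 2 bears on it only loosely. Its size, a 30-fold higher number from compound 1 to compound 2 (1.48 log units; beyond the scatter), shows that one change can move this assay a long way, but it gives no direction for this one. The data therefore support no expected shift beyond the scatter, though the uncertainty is wide in both directions. The estimated step is a 1.2-fold higher number from compound 2 to compound 3 (0.07 log units; within the scatter). For compound 3 the expected value is 25 uM, with an estimated range of 8 uM to 70 uM.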

Compound 3, concentration for half-maximal effect: 9.9 uM
Estimate against measurement, compound 3: 2.5-fold (0.40 log units) above; the measured number falls inside the stated range.
By their numbers in this assay, from the lowest: compound 1; then compound 3; then compound 2.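

Ethyl in place of hydrogen on the oxygen on the aromatic ring gives the first measured step at this position: a 2.2-fold lower number from compound 2 to compound 3 (0.33 log units; beyond the scatter) in this assay, modest in size but beyond the scatter. With the hydroxymethyl held constant, the free hydroxy is therefore not needed for a measurable effect, and hydroxy to ethoxy shifts the read-out towards smaller amounts of compound, though far less than the change at the other position, a 30-fold higher number from compound 1 to compound 2 (1.48 log units; beyond the scatter). Nothing available accounts for the direction or size of this shift, so it stands as an observation only.

From the compounds shown here alone, this single step is read only with hydroxymethyl in place, so it remains open whether ethyl on this oxygen would move the number in the same direction or by a similar amount alongside the carboxy of compound 1. Going by these compounds, it is also open whether the result is particular to ethyl or extends to methyl, to a longer chain such as propyl, or to a chain ending in an amine on the same oxygen.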